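Side chain change from compound 3 to compound 4

A few compounds are considered here, and "the series" means these few. Any claim that something is new, unique, unknown or untested is made for them only; others in the source may bear on it.

In a functional assay on MCF7 cells (Homo sapiens) for antiproliferative activity, read by MTT assay (on this read-out higher numbers stand for weaker inhibition and lower numbers for stronger inhibition), compound 3 (`CCCC/C=C\CCCCCCCCCc1cc(=O)c2c(O)cc(O)cc2o1`) gives 17500 nM, and compound 1 (`CC/C=C\C/C=C\C/C=C\CCCCCCCc1cc(=O)c2c(O)cc(O)cc2o1`) gives 17500 nM, so the two stand level. Compound 2 (`CCCCC/C=C\C/C=C\CCCCCCCc1cc(=O)c2c(O)c(C)c(O)cc2o1`) gives > 84100 nM, which is a limit of the assay and not a number. No measured single change connects compound 2 to the other two, so it sets no step size here.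

Compound 4 (`CCCCC/C=C\C/C=C\CCCCCCCc1cc(=O)c2c(O)cc(O)cc2o1`) has not yet been measured. Its difference from compound 3 is deca-1,4-dien-1-yl in place of oct-3-en-1-yl on a saturated chain carbon, seven bonds along the chain from an aromatic carbon. In words, deca-1,4-dien-1-yl stands in place of oct-3-en-1-yl on a saturated chain carbon, seven bonds along the chain from an aromatic carbon.

Among the measured compounds shown here, only one measured step bears on this: no change at the digits printed from compound 1 to compound 3 (within the scatter). It also exchanges one side chain for another at that place, and it stays within the scatter. This is a single step, so the support is thin, but no shift beyond the scatter is expected in this assay. The expected change is a 1.0-fold higher number from compound 3 to compound 4 (0.01 log units; within the scatter). For compound 4 the estimated value is 18000 nM, with an expected range of 8000 nM to 42000 nM.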

Compound 4, half-maximal inhibitory concentration: 17500 nM
Beside the measured number, compound 4's estimate is 1.0-fold (0.01 log units) above it, and the stated range covers the measured number.
By their numbers in this assay, from the lowest: compounds 1, 3 and 4 (each within the scatter of the next). At a limit, above all of these: compound 2.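

In this assay, the side chain again leaves the number unmoved, now across three chains: no change at the digits printed from compound 3 to compound 4 (within the scatter), and no change at the digits printed from compound 1 to compound 4 (within the scatter). Compound 2 gives > 84100 nM, which is a limit of the assay. Among the compounds shown here, the first step beyond the scatter comes from a change on the shared core rather than on the chain, with hydrogen in place of methyl on an aromatic carbon, an at least 4.8-fold lower number from compound 2 to compound 4 (0.68 log units; beyond the scatter), and its size rests on a limit: the limit of > 84100 nM in this assay, at which 1 of the 4 values shown sits.

From the compounds shown here alone, whether the side chain stays this silent with a much shorter chain, or with one ending in an amine or a carboxylic acid, remains open. Also open, going by these compounds, is whether the methyl step holds with the other two chains, and how ethyl or chlorine would read on that aromatic carbon.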